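The source may hold more compounds than are shown below. What is called first, only, known or untested is meant among the compounds shown, and "the series" means these compounds.

In an assay on CHO cells for displacement of a labelled ligand from melatonin receptor type 1A (Homo sapiens), with a stated time of 120 min (a lower number here means a stronger inhibitor, a higher number a weaker inhibitor), compound 1 `CCC(=O)NCC1CCc2ccc(OC)cc2N1Cc1ccccc1` gives 214 nM, the lowest of the two numbers that have so far been measured. Compound 2 `CCNC(=O)NCC1CCc2c(cccc2OC)N1` gives 480 nM in this assay, a number that stands beyond the usual scatter above the value of compound 1. Compound 3 `CCC(=O)NCc1ccc2c(OC)cccc2n1` did not yield a number in this assay but only a limit, > 10000 nM. That one value among the three sits at the limit of > 10000 nM in this assay, at which 1 of the 3 values shown sits.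

Compound 4 `CCC(=O)NCC1CCc2ccccc2N1Cc1ccccc1` has not yet been measured in this assay. It differs from compound 1 in a single place: hydrogen in place of methoxy on an aromatic carbon. Among the measured compounds no pair differs in only one place, so there is no measured step to set against this change, and the expectation for it rests on the change itself. The methoxy is lost and nothing but a hydrogen takes its place on the shared core of compound 1. The step from compound 1 to compound 4 is expected to run toward weaker inhibition, by about a 14-fold higher number from compound 1 to compound 4 (1.15 log units; beyond the scatter), well beyond the scatter. In this assay compound 4 is therefore expected to give roughly 3000 nM, most likely somewhere between 800 nM and 10000 nM, with some chance that only a limit is reported.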

Compound 4, inhibition constant: 37 nM
Beside the measured number, compound 4's estimate is 81-fold (1.91 log units) above it, and the stated range ends above it.
By their numbers in this assay, from the lowest: compound 4; then compound 1; then compound 2. At a limit, above all of these: compound 3.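

Hydrogen in place of methoxy on an aromatic carbon, meta to a fused ring and para to a fused ring, gives a 5.8-fold lower number from compound 1 to compound 4 (0.76 log units; beyond the scatter) in this assay, so the methoxy at this place is not required for inhibition in this range, and of the two compounds the one carrying it has the higher number. Among these compounds, this is the first step between measured compounds that differ in one place, and so the first direct reading of any single group on this core; compound 2 and compound 3 each differ from compound 1 in more than one place and could not show what this methoxy contributes. No evidence at hand bears on why the step runs in this direction.

The compounds shown leave open whether another group at this place, such as a fluorine, a hydroxyl or a longer ethoxy chain, would keep, lower or raise the number of compound 4. Among the compounds shown here, they also leave open whether the same exchange would run the same way with a different side chain on the shared core; only this one pair can be read so far.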